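A few compounds are considered here, and "the series" means these few. Any claim that something is new, unique, unknown or untested is made for them only; others in the source may bear on it.

Three sulfonamides built on a shared core have been tested in an ADME assay on HEK293 cells (Homo sapiens) for cytotoxicity, read by resazurin assay, with a stated time of 48 h; a lower number here means that less compound is tolerated, a higher number that more compound is tolerated. Compound 1 `COc1ccc(Cl)cc1S(=O)(=O)Nc1ccc(-c2nc3ccccc3o2)cc1` gives 75000 nM in this assay. Compound 2 `O=S(=O)(Nc1ccc2oc(-c3ccccc3)nc2c1)c1cccs1` gives 97000 nM in this assay, a number that lies within the usual scatter of the value of compound 1, so the two stand on a par. Compound 3 `O=S(=O)(Nc1ccc(-c2nc3ccccc3o2)cc1)c1cccc(C(F)(F)F)c1` reached only a limit of this assay, recorded as > 100000 nM. Compound 3 thus sits at the limit of > 100000 nM in this assay, at which 1 of the 3 values shown sits. Among the measured compounds shown here, none of these three pairs differs in a single place, so no measured step can be drawn between them; all that can be said is that every number gathered so far lies at the high, well-tolerated end.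

Compound 4 `O=S(=O)(Nc1ccc2oc(-c3ccccc3)nc2c1)c1ccccc1F` has not yet been measured in this assay. It differs from compound 2 in one place: 2-fluorophenyl in place of thiophen-2-yl on a sulfonyl sulfur. Because compound 2 gives 97000 nM and compound 1 gives 75000 nM with unlike groups on the sulfonyl sulfur, a different group there is expected to matter little. For compound 4 the expected step from its parent is therefore small, a 1.1-fold lower number from compound 2 to compound 4 (0.03 log units; within the scatter), not beyond the scatter. Compound 4 is estimated to give about 90000 nM in this assay, expected to fall between 40000 nM and 150000 nM, with a real chance that only a limit is recorded.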

Compound 4, half-maximal cytotoxic concentration: 72000 nM
For compound 4 the middle estimate is 1.3-fold (0.10 log units) above the measured one; the measured number falls inside the stated range.
By their numbers in this assay, from the lowest: compounds 4, 1 and 2 (each within the scatter of the next). At a limit, above all of these: compound 3.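

Among the compounds shown here, this is the first step measured directly at the group on the sulfonyl sulfur. With the rest of compound 2 held fixed, putting 2-fluorophenyl in place of thiophen-2-yl gives a 1.3-fold lower number from compound 2 to compound 4 (0.13 log units; within the scatter) in this assay. Compound 1 and compound 2 differ in more than one place, so they could only hint that this position matters little, whereas this pair tests it directly: a five-membered aromatic ring with a sulfur atom and a six-membered aromatic ring of carbon only, carrying fluorine, stand on a par here. This is one pair on one core, however, and it sets no general rule for the position.

As far as these compounds go, both rings are aromatic, so it remains open whether a group of another kind on the sulfonyl sulfur, such as a plain methyl group or a phenyl ring carrying a carboxylic acid or an amine, would move the number beyond the scatter. How far compound 3 lies from the other compounds also cannot be told, as its entry is a limit and not a number: the limit of > 100000 nM in this assay, at which 1 of the 4 values shown sits.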